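The source may report more compounds than this note shows. Statements on the series, on what has been measured and on what is new or still open speak of the compounds shown alone.

Among the measured compounds shown here, compound 3 `O=C(COCc1ccncn1)N1CCN(c2ccc(Cl)cc2Cl)CC1` gives 2800 nM in a functional assay on HEK293 cells for positive allosteric modulation of metabotropic glutamate receptor 5 (Homo sapiens), read by FLIPR and calcium flux (a lower number here means that less compound is needed, a higher number that more compound is needed for the effect), the second highest of the three numbers measured so far; compound 2 `O=C(COCc1cnccn1)N1CCN(c2ccc(Cl)cc2Cl)CC1` gives 5200 nM, and compound 1 `O=C(COCc1ccccc1)N1CCN(c2ccc(Cl)cc2)CC1` gives 350 nM. Compound 4 `O=C(COCc1nccs1)N1CCN(c2ccc(Cl)cc2Cl)CC1` has not been measured; it differs from compound 3 by 1,3-thiazol-2-yl in place of pyrimidin-4-yl on a saturated chain carbon bound to an oxygen on a saturated carbon. For the measured compounds named here, the only measured step at this place is a 1.9-fold lower number from compound 2 to compound 3 (0.27 log units; within the scatter), a swap between two six-membered rings, and it stayed within the scatter. Going by the values given here, no measured step exchanges a six-membered for a five-membered ring here, and compound 1 differs from compound 3 at more than one place, so its number does not isolate this position. Compound 4 is therefore expected to give 2800 nM, with a range from 1000 nM to 7500 nM. The expected step is no change at the digits printed from compound 3 to compound 4 (within the scatter), not beyond the scatter.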

Compound 4, half-maximal effective concentration: 10300 nM
Compound 4: middle estimate off by 3.7-fold (0.57 log units), on the low side, and the stated range ends below it.
By their numbers in this assay, from the lowest: compound 1; then compounds 3, 2 and 4 (each within the scatter of the next, the first and the last beyond it).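

In this assay, among the compounds shown here, this place, on a saturated chain carbon bound to an oxygen on a saturated carbon, does respond to a ring exchange: 1,3-thiazol-2-yl in place of pyrimidin-4-yl gives a 3.7-fold higher number from compound 3 to compound 4 (0.57 log units; beyond the scatter), the first step here beyond the scatter. In place of pyrazin-2-yl, the same five-membered ring gives a 2.0-fold higher number from compound 2 to compound 4 (0.30 log units; within the scatter), so the reading depends on which six-membered ring leaves. Nothing available accounts for the step. On these data alone, whether the sulfur or the ring size carries the step stays open, and a 1,3-oxazol-2-yl or pyridin-2-yl ring at this place would help separate the two.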